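Cyclohexyl in place of 4-(dimethylamino)phenyl in compound 3

The source may hold more compounds than are shown below. What is called first, only, known or untested is meant among the compounds shown, and "the series" means these compounds.

- compound 1 `COc1ccc(C(c2c[nH]c3ccc(Br)cc23)c2c[nH]c3ccc(Br)cc23)c(OC)c1` gives 77500 nM in a functional assay on MCF7 cells (Homo sapiens) for inhibition, read by MTT assay, with a stated time of 48 h; a lower number here means a stronger inhibitor, a higher number a weaker inhibitor
- compound 2 `COc1ccc(C(c2c[nH]c3ccc(Br)cc23)c2c[nH]c3ccc(Br)cc23)cc1OC` gives 7800 nM
- compound 3 `CN(C)c1ccc(C(c2c[nH]c3ccc(Br)cc23)c2c[nH]c3ccc(Br)cc23)cc1` gives 24900 nM

Compound 3 holds the second highest of these three numbers, beyond the scatter from both others. Compound 4 `Brc1ccc2[nH]cc(C(c3c[nH]c4ccc(Br)cc34)C3CCCCC3)c2c1` has not yet been measured. It carries cyclohexyl in place of 4-(dimethylamino)phenyl on a saturated chain carbon bound to two aromatic carbons. For the measured compounds named here, no measured step makes this change, since each one only exchanges one phenyl group for another. Those steps, a 3.1-fold lower number from compound 1 to compound 3 (0.49 log units; beyond the scatter) and a 3.2-fold higher number from compound 2 to compound 3 (0.50 log units; beyond the scatter), are modest and run in opposite directions, so they give size but no direction. The expected step is a 1.0-fold higher number from compound 3 to compound 4 (0.00 log units; within the scatter), with either direction possible. In this assay compound 4 is estimated at 25000 nM, within an expected range of 7000 nM to 80000 nM.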

Compound 4, half-maximal inhibitory concentration: 4100 nM
Beside the measured number, compound 4's estimate is 6.1-fold (0.79 log units) above it; measured number outside the range, below it.
By their numbers in this assay, from the lowest: compounds 4 and 2 (each within the scatter of the next); then compound 3; then compound 1.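

At the saturated chain carbon bound to two aromatic carbons, this assay shows that a phenyl group can be replaced by cyclohexyl, a non-aromatic ring with no hydrogen-bond acceptor, without loss: the change gives a 6.1-fold lower number from compound 3 to compound 4 (0.78 log units; beyond the scatter) and a 19-fold lower number from compound 1 to compound 4 (1.28 log units; beyond the scatter) as its larger steps. Against the 3,4-dimethoxyphenyl group, it gives a 1.9-fold lower number from compound 2 to compound 4 (0.28 log units; within the scatter) and so stands level with that group. No measurement shown explains these steps. Going by these compounds, whether cyclopentyl, an open hexyl chain or a cyclohexyl ring carrying an amine would keep this number remains open.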